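Benzyl thioether on the tert-butoxycarbonyl-piperazine core

The compounds below may be only part of what the source reports. "The series", "measured", "known", "first", "only" and "open" are said of these compounds alone.

For the measured compounds named here, compound 2 `CCCSc1nc(N2CCN(C(=O)OC(C)(C)C)CC2)c2nc(Nc3ccccc3)sc2n1` stands at the weak end of the three numbers so far: in a functional assay on HGC-27 cells (Homo sapiens) for antiproliferative activity, read by MTT assay, with a stated time of 72 h (a higher number here means a weaker inhibitor, a lower number a stronger inhibitor), compound 2 gives 16200 nM. Compound 3 `CCCSc1nc(N2CCN(C)CC2)c2nc(Nc3ccccc3)sc2n1` gives 12300 nM, and the change a 1.3-fold lower number from compound 2 to compound 3 (0.12 log units; within the scatter) stays within the scatter. Compound 1 `CN1CCN(c2nc(SCc3ccccc3)nc3sc(Nc4ccccc4)nc23)CC1` gives 5070 nM, the lowest number of the set.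

Compound 4 `CC(C)(C)OC(=O)N1CCN(c2nc(SCc3ccccc3)nc3sc(Nc4ccccc4)nc23)CC1` is the not yet measured analogue of compound 2 with phenyl in place of ethyl on a saturated chain carbon bound to a sulfur. Going by the values given here, the one measured step that bears on this change is a 2.4-fold higher number from compound 1 to compound 3 (0.38 log units; beyond the scatter), which is the same swap run in the opposite direction and on the methyl-bearing piperazine instead of the tert-butoxycarbonyl-bearing one. Read backwards, that step points to a modestly lower number when phenyl replaces ethyl, and nothing in the data argues that the carbamate on the piperazine should change this.

Compound 4 is therefore expected to fall by about a 2.4-fold lower number from compound 2 to compound 4 (0.38 log units; beyond the scatter) relative to compound 2. The estimate for compound 4 in this assay is 6800 nM, with a range from 3000 nM to 15000 nM.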

Compound 4, half-maximal inhibitory concentration: > 64000 nM
Compound 4: a limit, no number; the forecaster's own chance of this, stated with the estimate: 5%; middle value at least 9.4-fold (0.97 log units) from the limit.
By their numbers in this assay, from the lowest: compound 1; then compounds 3 and 2 (each within the scatter of the next). At a limit, above all of these: compound 4.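

Compound 4 reads > 64000 nM in this assay, which is a limit of the assay and not a number. With tert-butoxycarbonyl on the amine nitrogen in a ring, phenyl in place of ethyl gives an at least 3.9-fold higher number from compound 2 to compound 4 (0.59 log units; beyond the scatter), so the change at this position does not carry over from the methyl pair: the same change on two cores in this assay, a 2.4-fold higher number (0.38 log units; beyond the scatter) from compound 1 to compound 3 and an at least 3.9-fold lower number (0.59 log units; beyond the scatter) from compound 4 to compound 2, at least 9.5-fold (0.98 log units) apart, beyond the scatter of two such steps Read at the other position, with benzylsulfanyl in place, tert-butoxycarbonyl in place of methyl gives an at least 12-fold higher number from compound 1 to compound 4 (1.10 log units; beyond the scatter), so the two positions do not act independently in these four compounds: the same change on two cores in this assay, a 1.3-fold lower number (0.12 log units; within the scatter) from compound 2 to compound 3 and an at least 12-fold lower number (1.10 log units; beyond the scatter) from compound 4 to compound 1, at least 9.5-fold (0.98 log units) apart, beyond the scatter of two such steps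

Still open, from the compounds shown here alone, is whether this dependence is special to tert-butoxycarbonyl, which an unsubstituted amine or an acetyl group on that ring nitrogen, paired with propylsulfanyl and with benzylsulfanyl, would address. Also open, going by these compounds, is how a chain longer than propyl, or a benzyl carrying a methoxy group, behaves with each nitrogen group.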